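The compounds below may be only part of what the source reports. "The series", "measured", "known", "first", "only" and "open" are said of these compounds alone.

Compound 1, `O=C(NO)[C@@H]1CSCN1Cc1ccc(-c2ccccc2)cc1`: in an assay on isolated protein for inhibition of matrix metalloproteinase-9 (Homo sapiens), read by fluorescence, with stated times of 1 h and 30 min (on this read-out higher numbers stand for weaker inhibition and lower numbers for stronger inhibition), compound 1 gives "not determined" (no result reported).
Compound 2, `O=C(NO)[C@@H]1CCC(=O)N1Cc1ccc(Cl)cc1`: in this assay compound 2 gives "not determined" (no result reported).
Compound 3, `O=C(NO)[C@@H]1CSCN1S(=O)(=O)c1ccc(-c2ccccc2)cc1`: in this assay compound 3 gives 230 nM.

Among the measured compounds shown here, compound 3 therefore carries the only number among the three measured compounds; compounds 1 and 2 offer no value to compare it with, so no step between measured compounds can be stated. The unmeasured compound 4, `O=C(NO)[C@@H]1CSCN1S(=O)(=O)c1ccc(Oc2ccc(Cl)cc2)cc1`, differs from compound 3 in one place: 4-chlorophenoxy in place of phenyl on an aromatic carbon. For the measured compounds named here, with no measured pair showing what such a change does here, the expectation rests on the structural change alone. A modest gain in potency, somewhat beyond the scatter, is estimated for the step of a 2.3-fold lower number from compound 3 to compound 4 (0.36 log units; beyond the scatter). Compound 4 is thus expected to give about 100 nM, within a range from 30 nM to 400 nM.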

Compound 4, half-maximal inhibitory concentration: 16 nM
Estimate against measurement, compound 4: 6.3-fold (0.80 log units) above; the whole stated range lies above it.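

In this assay, putting 4-chlorophenoxy in place of phenyl on this aromatic carbon gives a 14-fold lower number from compound 3 to compound 4 (1.16 log units; beyond the scatter), so this position, para to a large group, is clearly sensitive to what sits there. The entering group keeps the single carbon ring and brings an oxygen and a chlorine with it. Nothing shown explains the gain.

From the compounds shown here alone, since the oxygen and the chlorine enter together, their separate shares remain open; plain phenoxy or 4-chlorophenyl would separate them. Going by these compounds, how an amine or a carboxylic acid on that ring would behave also remains open.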